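The source may hold more compounds than are shown below. What is called first, only, known or untested is meant among the compounds shown, and "the series" means these compounds.

Measured compounds in a functional assay on THP-1 cells (Homo sapiens) for antiproliferative activity, tested at 20 uM; on this read-out higher numbers stand for a stronger effect at the one concentration tested and lower numbers for a weaker effect:
compound 1 `COC(=O)c1ccc(CS(=O)(=O)Nc2ccc3c(c2)cc(C)c(=O)n3C)cc1` gives 9%
compound 2 `COc1ccc(C(=O)NOCc2ccc(OC(C)=O)cc2)cc1S(=O)(=O)Nc1ccc2c(c1)cc(C)c(=O)n2C` gives 3%
compound 3 `COc1ccc(C(=O)NO)cc1CS(=O)(=O)Nc1ccc2c(c1)cc(C)c(=O)n2C` gives 0%

In this assay compound 3 stands at the bottom of the three numbers, yet the gap to compound 2 and the gap to compound 1 both lie within the usual scatter of repeated measurements, so the three compounds cannot be told apart on these data. None of them shows a clear effect at the single concentration tested.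

Compound 4 `Cc1cc2cc(NS(=O)(=O)Cc3cccc(C(=O)NO)c3)ccc2n(C)c1=O` has not yet been measured. It differs from compound 3 in one place: hydrogen in place of methoxy on an aromatic carbon. No step between measured compounds of this set shows what such a change does, so there is no shown step to lean on. Given that compound 3 gives 0% and that none of the three measured compounds shows a clear effect in this assay, the step from compound 3 to compound 4 is expected to be small, a number 3 percentage points higher from compound 3 to compound 4 (within the scatter), with no direction beyond the scatter. Compound 4 is therefore estimated at 3%, in a range from -5% to 12%.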

Compound 4, a percentage reported as inhibition, at one concentration (the size of the read-out at that concentration, not a potency): 0%
For compound 4 the middle estimate is 3 percentage points above the measured one; the measured number falls inside the stated range.
By their numbers in this assay, from the lowest: compounds 3, 4, 2 and 1 (each within the scatter of the next).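

In this assay, hydrogen in place of methoxy on the aromatic carbon para to the hydroxycarbamoyl group brings no change at the digits printed from compound 3 to compound 4 (within the scatter). Within the data shown here, this is the first pair in the set that differs in one place, and it shows that taking the methoxy off this carbon does not bring out a clear effect at the one concentration tested. Nothing at hand explains this outcome.

Still open, as far as these compounds go, is whether another group on this aromatic carbon, such as an amine, a carboxylic acid or a fluorine atom, would move the number beyond the scatter. From the compounds shown here alone, neither compound 3 nor compound 4 shows a clear effect, so it also remains open how the same change would read in a compound that does show one.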